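A Methyl Added to the Pendant Phenyl of Compound 3

The source may report more compounds than this note shows. Statements on the series, on what has been measured and on what is new or still open speak of the compounds shown alone.

Compound 1, `CC(C)=CCOc1ccc2c(c1)OC(c1ccc(Cl)cc1Cl)CC2=O`: in a functional assay (on this read-out higher numbers stand for weaker inhibition and lower numbers for stronger inhibition), compound 1 gives 5260 nM.
Compound 2, `COc1ccc(C2CC(=O)c3ccc(OCC=C(C)C)cc3O2)c(OC)c1`: in this assay compound 2 gives 8180 nM.
Compound 3, `CC(C)=CCOc1cc(O)c2c(c1)OC(c1ccccc1)CC2=O`: in this assay compound 3 gives 7320 nM.

These three compounds share a core and differ in the groups hung on it. Compound 3 stands second highest of the three numbers. Its nearest neighbour is compound 2, and even its furthest, compound 1, sits within the usual scatter of this kind of measurement, so the three values cannot be told apart.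

Compound 4, `CC(C)=CCOc1cc(O)c2c(c1)OC(c1ccc(C)cc1)CC2=O`, differs from compound 3 in one place: methyl in place of hydrogen on an aromatic carbon. Cut one bond further out, the same difference reads phenyl to 4-methylphenyl.

For the measured compounds named here, no two measured compounds differ in a single place, so there is no measured step to lean on. The change adds a single carbon to the pendant ring. The step of a 1.1-fold lower number from compound 3 to compound 4 (0.05 log units; within the scatter) is expected to stay within the scatter, with no clear direction. Compound 4 is therefore expected to give 6500 nM in this assay, within a range from 3000 nM to 14000 nM.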

Compound 4, half-maximal inhibitory concentration: 4360 nM
Compound 4: the middle estimate sits 1.5-fold (0.17 log units) above what was measured; the range from low to high includes it.
By their numbers in this assay, from the lowest: compounds 4, 1, 3 and 2 (each within the scatter of the next).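

Methyl in place of hydrogen on an aromatic carbon, para to a large group, gives a 1.7-fold lower number from compound 3 to compound 4 (0.23 log units; within the scatter) in this assay, and this is the first step here between two compounds that differ in one place. It shows that this position can carry one added carbon without a shift that can be told apart from the variation between repeated measurements, though a single pair cannot set a trend. Nothing measured here offers an explanation for this result.

As far as these compounds go, whether this position responds to anything other than methyl remains open: an amine, a carboxylic acid or a longer chain such as butyl could move the number beyond the scatter, or could leave it where it is. From the compounds shown here alone, it is also open whether the same methyl would give a similar step on a compound lacking the hydroxyl of compound 3.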